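A few compounds are considered here, and "the series" means these few. Any claim that something is new, unique, unknown or untested is made for them only; others in the source may bear on it.

Of the compounds shown here, two have numbers so far. Compound 1 `Fc1ccc(C(SCCNC2CCN(Cc3ccc(C(F)(F)F)cc3)CC2)c2ccc(F)cc2)cc1` gives 190 nM in an assay on membranes from striatum (strain Sprague-Dawley) for displacement of a labelled ligand from sodium-dependent dopamine transporter (Rattus norvegicus), read by scintillation counting, with a stated time of 120 min; on this read-out lower numbers stand for stronger inhibition and higher numbers for weaker inhibition. Compound 2 `[O-][S+](CCNC1CCN(CC(O)Cc2ccccc2)CC1)C(c1ccc(F)cc1)c1ccc(F)cc1` gives 91.8 nM in this assay, the lowest of the two numbers, with compound 1 at a higher number beyond the scatter. Compound 3 `O=C(c1ccc(F)cc1F)N1CCC(NCC[S+]([O-])C(c2ccc(F)cc2)c2ccc(F)cc2)CC1` is not yet measured; it differs from compound 2 in one place: (2,4-difluorophenyl)carbonyl in place of 2-hydroxy-3-phenylpropyl on an amine nitrogen in a ring. Among the compounds with values here, no measured pair shows a step of this kind, so the expected step from compound 2 to compound 3, a 2.7-fold higher number from compound 2 to compound 3 (0.44 log units; beyond the scatter), is a guess toward a higher number. For compound 3 the estimate in this assay is 250 nM, within 60 nM to 1000 nM.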

Compound 3, inhibition constant: 564 nM
Compound 3: middle estimate off by 2.3-fold (0.35 log units), on the low side, and the stated range covers the measured number.
By their numbers in this assay, from the lowest: compound 2; then compound 1; then compound 3.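

In this assay, within the data shown here, the change to (2,4-difluorophenyl)carbonyl in place of 2-hydroxy-3-phenylpropyl on an amine nitrogen in a ring is a 6.1-fold higher number from compound 2 to compound 3 (0.79 log units; beyond the scatter) and is the only single-place step so far. The number at this position therefore depends on the group it carries, although both groups count 10 heavy atoms and one six-membered aromatic ring. Nothing measured here bears on what lies behind the step.

The two compounds do not separate the effect of the entering carbonyl from that of the leaving hydroxyl. A 3-phenylpropyl group without the hydroxyl, or a 2,4-difluorobenzyl group, on the same nitrogen would separate them.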